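Methylating the pyrazole nitrogen on a second core

This account rests on a few compounds, and the source may have more. Where it says the series, first, only, none or still open, it means among the compounds named here.

Measured so far:
compound 1 `CC(=O)Nc1cc(-c2c(Nc3cc[nH]n3)nc3ccccn23)nc(C)n1` gives 1.2 L/kg
compound 2 `CC(=O)Nc1cc(-c2c(Nc3cc[nH]n3)nc3cccnn23)nc(C)n1` gives 6.3 L/kg
compound 3 `CC(=O)Nc1cc(-c2c(Nc3ccn(C)n3)nc3ccccn23)nc(C)n1` gives 0.6 L/kg

These three compounds were tested in an in vivo ADME assay on the whole organism for pharmacokinetics, with Rattus norvegicus as the target, at a dose of 0.5 mg/kg by the intravenous route; on this read-out lower numbers stand for narrower distribution and higher numbers for wider distribution into tissues. Compound 1 gives 1.2 L/kg in this assay, and compound 3, which carries methyl in place of hydrogen on an aromatic nitrogen, gives 0.6 L/kg. The step from one to the other is small: a 2.0-fold lower number from compound 1 to compound 3 (0.30 log units; within the scatter). Compound 2 shares most of its structure with compound 1 but has a different core; the difference between the two cores is not broken down here. Compound 2 gives 6.3 L/kg in this assay, the highest of the three numbers, and its gaps to compound 1 and to compound 3 both lie beyond the usual scatter.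

Compound 4 `CC(=O)Nc1cc(-c2c(Nc3ccn(C)n3)nc3cccnn23)nc(C)n1` has not yet been measured. It stands to compound 2 as compound 3 stands to compound 1: it carries methyl in place of hydrogen on an aromatic nitrogen, the same change at the same place. Going by the values given here, the only guide to what this change does is the pair of compound 1 and compound 3, where the step was a 2.0-fold lower number from compound 1 to compound 3 (0.30 log units; within the scatter) and stayed within the scatter. The expectation is therefore that the change from compound 2 to compound 4 brings a similarly small step, a 1.8-fold lower number from compound 2 to compound 4 (0.26 log units; within the scatter), starting from the higher number of compound 2 at 6.3 L/kg. On that basis compound 4 is expected to give about 3.5 L/kg in this assay, somewhere between 1.3 L/kg and 9 L/kg.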

Compound 4, volume of distribution at steady state: 0.8 L/kg
Compound 4: the middle estimate sits 4.4-fold (0.64 log units) above what was measured; the whole stated range lies above it.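

In this assay, replacing 1H-pyrazol-3-yl with 1-methyl-1H-pyrazol-3-yl on the core of compound 2 gives a 7.9-fold lower number from compound 2 to compound 4 (0.90 log units; beyond the scatter). This is a clear change, whereas the same replacement on the core of compound 1 stays within the scatter, so the size of the step does not carry over from one core to the other: the same change on two cores in this assay, a 2.0-fold lower number (0.30 log units; within the scatter) from compound 1 to compound 3 and a 7.9-fold lower number (0.90 log units; beyond the scatter) from compound 2 to compound 4, 3.9-fold (0.60 log units) apart, beyond the scatter of two such steps

Going by these compounds alone, this rests on only one matched pair for each core, so it shows that the core can matter for this change but does not explain why, and it offers no rule for predicting the step on any further core.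

The compounds shown leave open whether an ethyl group or a longer chain on the same ring nitrogen would also give steps that differ between these two cores. They also leave open whether a change at another place, such as a carboxylic acid in place of the acetyl group's methyl, would depend on the core in the same way.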